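A few compounds are considered here, and "the series" means these few. Any claim that something is new, unique, unknown or untested is made for them only; others in the source may bear on it.

Three compounds have been measured in an ADME assay on the whole organism with Oryza sativa as the target, tested at 1 uM; a lower number here means a stronger effect, a higher number a weaker effect of the compound at the concentration tested:

Compound 1, `C[C@@H](NC(=O)Nc1ccccc1Cl)c1ccccc1`, gives 103%.
Compound 2, `C[C@H](NC(=O)Nc1cccc(Cl)c1)c1ccccc1`, gives 99%.
Compound 3, `C[C@H](NC(=O)Nc1cc(Cl)ccc1Cl)c1ccccc1`, gives 99%.

All three values lie within the usual scatter of one another, so none of them can be said to act more strongly or more weakly than another at this concentration. Compound 1 and compound 2 are built from the same atoms joined differently; the difference between the two cores is not broken down here. From compound 2 to compound 3 the change is chloro in place of hydrogen on an aromatic carbon, and the measured step is no change at the digits printed from compound 2 to compound 3 (within the scatter).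

Compound 4, `C[C@@H](NC(=O)Nc1c(Cl)cccc1Cl)c1ccccc1`, has not yet been measured. It differs from compound 1 by chloro in place of hydrogen on an aromatic carbon. Going by the values given here, this is the same kind of change as the one from compound 2 to compound 3, but not the same: in compound 3 the entering chloro stands para to a chloro group, in compound 4 it stands meta to a chloro group. Resting on no change at the digits printed from compound 2 to compound 3 (within the scatter), which lies within the scatter, the expected step is a number 3 percentage points lower from compound 1 to compound 4 (within the scatter). Compound 4 is therefore estimated at 100%, with a likely range from 90% to 110%.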

Compound 4, a percentage reported as activity, at one concentration (the size of the read-out at that concentration, not a potency): 99%
Beside the measured number, compound 4's estimate is 1 percentage points above it, and the stated range covers the measured number.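

In this assay, the same swap of a hydrogen for a chloro on an aromatic carbon leaves the read-out a number 4 percentage points lower from compound 1 to compound 4 (within the scatter), and the two cores can be compared directly: the same change on two cores in this assay, no change at the digits printed (within the scatter) from compound 2 to compound 3 and a number 4 percentage points lower (within the scatter) from compound 1 to compound 4, 4 percentage points apart, within the scatter of two such steps. Within these compounds the change therefore carries from one core to the other in a limited sense, since on neither core does it move the number beyond what repeated measurements would give. Going by these compounds alone, it does not show that the two cores respond alike to a change with a real effect, since both steps are too small to tell apart from no step at all.

The compounds shown differ only in chloro groups on one aromatic ring, so it remains open whether another group there, such as a methoxy, a nitrile or an amine, would give a clearly different read-out. Going by these compounds, it also remains open whether these compounds would separate at a different concentration.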